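Series notes: from ester side chain to free hydroxy

The source may report more compounds than this note shows. Statements on the series, on what has been measured and on what is new or still open speak of the compounds shown alone.

Compound 3 `CCOC(=O)COc1cc(OC)ccc1-c1cc(-c2ccccc2)no1` stands lowest of the three numbers available. In a functional assay on the whole organism (blood, strain Charles Foster/Wistar albino) with Rattus norvegicus as the target, with a stated time of 30 min, at a dose of 100 mg/kg by the oral route (on this read-out lower numbers stand for less inhibition and higher numbers for more inhibition at the one dose given (going by the name of the read-out)), compound 3 gives 10.4%. Its nearest neighbour is compound 1 `CCN(CC)CCCOc1cc(OC)ccc1-c1cc(-c2ccccc2)no1`, which in this assay gives 14.3%; the step of a number 3.9 percentage points lower from compound 1 to compound 3 (within the scatter) stays within the scatter. Furthest away is compound 2 `COc1ccc(-c2cc(-c3ccccc3)no2)c(OCCCN2CCCC2)c1`, which in this assay gives 21.2%; the step of a number 10.8 percentage points lower from compound 2 to compound 3 (beyond the scatter) lies beyond the scatter, though only modestly. The step of a number 6.9 percentage points higher from compound 1 to compound 2 (within the scatter) stays within the scatter.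

Compound 4 `COc1ccc(-c2cc(-c3ccccc3)no2)c(O)c1` is not yet measured. Compared with compound 3 it carries hydrogen in place of (ethoxycarbonyl)methyl on an oxygen on an aromatic ring. Within the data shown here, no measured step removes a side chain altogether; the two steps that touch this position, a number 3.9 percentage points lower from compound 1 to compound 3 (within the scatter) and a number 10.8 percentage points lower from compound 2 to compound 3 (beyond the scatter), swap one chain for another and are both small. The whole spread of the three measured compounds is narrow, and nothing in it points to a larger move for a shorter substituent. The step of a number 1.6 percentage points higher from compound 3 to compound 4 (within the scatter) is therefore expected to stay small. Compound 4 is estimated to give 12% in this assay, with a range from 2% to 24%.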

Compound 4, a percentage reported as inhibition, in the whole organism at one dose (the size of the read-out at that dose, not a potency): 9.8%
Compound 4: middle estimate off by 2.2 percentage points, on the high side; the range from low to high includes it.
By their numbers in this assay, from the lowest: compounds 4, 3, 1 and 2 (each within the scatter of the next, the first and the last beyond it).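

In this assay the replacement of (ethoxycarbonyl)methyl by hydrogen on the oxygen on the aromatic ring gives a number 0.6 percentage points lower from compound 3 to compound 4 (within the scatter) and the replacement of 3-(diethylamino)propyl by hydrogen at the same place gives a number 4.5 percentage points lower from compound 1 to compound 4 (within the scatter) so neither chain can be told apart from the free hydroxy on this read-out. The 3-(pyrrolidin-1-yl)propyl chain is the only one of the three that separates from hydrogen, with a number 11.4 percentage points lower from compound 2 to compound 4 (beyond the scatter) and this separation is modest and rests on a single compound. No measurement in hand accounts for the difference between the chains.

Open, going by these compounds, is whether the free carboxylic acid on the same short chain, or a piperidine or morpholine at the end of the propyl chain, would stand with the pyrrolidine compound or with the free hydroxy, and whether a longer chain ending in pyrrolidine would widen the gap to hydrogen. With a single dose and a narrow spread of values, the read-out also leaves open how these compounds would compare at other doses or times.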